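The source may hold more compounds than are shown below. What is called first, only, known or untested is meant among the compounds shown, and "the series" means these compounds.

Measured compounds:
Compound 1 `N/C(=N\NC(=S)N1CCCCCC1)c1ccccn1`: in a functional assay on MCF7 cells (Homo sapiens) for cytotoxicity, read by MTT assay, with a stated time of 72 h, tested at 3 uM (a higher number here means more inhibition of growth at the concentration tested, a lower number less inhibition of growth), compound 1 gives 56%.
Compound 2 `Cc1cccc(/C(N)=N/NC(=S)N2CCCCCC2)n1`: in this assay compound 2 gives 15.7%.

For the measured compounds named here, of these two numbers, compound 1 stands highest; its nearest neighbour is compound 2, and the single measured step, a number 40.3 percentage points lower from compound 1 to compound 2 (beyond the scatter), came with a methyl in place of hydrogen on an aromatic carbon. Compound 3 `N/C(=N\NC(=S)N1CCCCCC1)c1ccc(F)cn1` is not yet measured. It differs from compound 1 by fluoro in place of hydrogen on an aromatic carbon. Going by the values given here, no measured step bears directly on this change: the only step known, that from compound 1 to compound 2, concerns a different group at a different place, and a methyl at that place cost a large amount. Among the compounds with values here, a fluoro at the position in compound 3 has no precedent here, so the expectation is uncertain; a modest loss or a step within the scatter seems most plausible. Compound 3 is therefore estimated at 45%, with a range from 15% to 65%, which means an expected step of a number 11 percentage points lower from compound 1 to compound 3 (beyond the scatter).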

Compound 3, percent growth inhibition at one concentration: 24.3%
Estimate against measurement, compound 3: 20.7 percentage points above, within the range that was stated.
By their numbers in this assay, from the lowest: compounds 2 and 3 (each within the scatter of the next); then compound 1.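

In this assay the fluoro group brings only one heavy atom to an aromatic carbon two atoms from the ring nitrogen, yet it comes with a number 31.7 percentage points lower from compound 1 to compound 3 (beyond the scatter) and so shows that even this small replacement of hydrogen at this place can cost much of the growth inhibition. Together with a number 40.3 percentage points lower from compound 1 to compound 2 (beyond the scatter) it makes two replacements of hydrogen on an aromatic carbon of compound 1, each with a large loss and neither keeping the level of compound 1, so the earlier drop no longer stands alone. No measurement here explains why the fluoro change lowers the number.

Still open, going by these compounds, is whether any group at this place brings such a loss or whether it is special to fluoro. A chloro, a methoxy or an amine at the same carbon would help separate these two readings.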